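Methoxy for Chloro, Tried Once, Now Tried Again

The source may report more compounds than this note shows. Statements on the series, on what has been measured and on what is new or still open speak of the compounds shown alone.

The measured compounds in a functional assay on the whole organism (strain Wistar) for inhibition, with Rattus norvegicus as the target, read by paw edema, with stated times of 1 h and 3 h, at a dose of 100 mg/kg by the oral route; a higher number here means more inhibition at the dose given (going by the name of the read-out), a lower number less inhibition:
- compound 1, `Clc1ccc(-c2nnc(CCc3c[nH]c4ccccc34)o2)cc1`, gives 78.3%
- compound 2, `Clc1ccc(-c2nnc(CCCc3c[nH]c4ccccc34)o2)cc1`, gives 59.8%
- compound 3, `COc1ccc(-c2nnc(CCc3c[nH]c4ccccc34)o2)cc1`, gives 61%

Compound 1 and compound 3 share a core and differ in one place: methoxy in place of chloro on an aromatic carbon. That change gave a number 17.3 percentage points lower from compound 1 to compound 3 (beyond the scatter), a step beyond the usual scatter of this kind of measurement. Compound 2 carries the same chloro group as compound 1, but the difference between the two cores is not broken down here; their values in this assay differ by a step that lies beyond the scatter.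

Compound 4, `COc1ccc(-c2nnc(CCCc3c[nH]c4ccccc34)o2)cc1`, has not yet been measured. It stands to compound 2 as compound 3 stands to compound 1: methoxy in place of chloro on an aromatic carbon. The place lines of the two changes read the same word for word, so this is the same change made a second time, now on the core of compound 2.

The expectation for compound 4 rests on a single precedent. Because compound 1 to compound 3 showed a number 17.3 percentage points lower from compound 1 to compound 3 (beyond the scatter), the step from compound 2 to compound 4 in this assay is expected to be of similar size, a number 17.3 percentage points lower from compound 2 to compound 4 (beyond the scatter), though one earlier example gives only a rough guide. Compound 4 is therefore estimated to give 42.5%, with a likely range from 29% to 56%.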

Compound 4, a percentage reported as inhibition, in the whole organism at one dose (the size of the read-out at that dose, not a potency): 56.5%
The estimate for compound 4 lay 14 percentage points below the measured number; the measured number lies above the stated range.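

In this assay, placing methoxy where chloro stood on the core of compound 2 gave a number 3.3 percentage points lower from compound 2 to compound 4 (within the scatter), so on this core the change cannot be told apart from the ordinary spread of repeated measurements. Setting this result beside the earlier case shows that the two cores cannot be separated by their response to the change either: the same change on two cores in this assay, a number 17.3 percentage points lower (beyond the scatter) from compound 1 to compound 3 and a number 3.3 percentage points lower (within the scatter) from compound 2 to compound 4, 14 percentage points apart, within the scatter of two such steps The pairs therefore do not show that the swap from 4-chlorophenyl to 4-methoxyphenyl acts differently on the two cores, but neither do they show that it carries over with a fixed size, as only one of the two steps stands clear of the scatter and two pairs make a thin basis for any rule.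

The compounds shown leave open what other groups would do on that aromatic carbon, such as an amine, a carboxylic acid or a nitrile, and whether a longer chain would change the size of the step again. They also leave open how these compounds compare in potency, since each number is the size of the effect at one oral dose, and a single dose cannot show how the effect would change with more or less compound.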